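Cyclohexyl for 2-phenylethenyl on the shared core

This account rests on a few compounds, and the source may have more. Where it says the series, first, only, none or still open, it means among the compounds named here.

Three compounds of the series have numbers in a functional assay on NCI-H1299 cells (Homo sapiens) for cytotoxicity, read by MTT assay, with a stated time of 48 h; a higher number here means a weaker inhibitor, a lower number a stronger inhibitor. Compound 1 `C=C(C)Cn1cc(CO[C@H]2CC(=O)[C@@H]3OC[C@H]2O3)nn1` gives 14300 nM. Compound 2 `O=C1C[C@H](OCc2cc(-c3ccc([N+](=O)[O-])cc3)no2)[C@H]2CO[C@@H]1O2` gives 11200 nM. Compound 3 `O=C1C[C@H](OCc2cc(/C=C/c3ccccc3)no2)[C@H]2CO[C@@H]1O2` gives 7100 nM, the lowest of the three numbers, but its gaps to compound 2 and to compound 1 both fall within the usual scatter, so no order among the three can be read from these values.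

Compound 4 `O=C1C[C@H](OCc2cc(C3CCCCC3)no2)[C@H]2CO[C@@H]1O2` differs from compound 3 in one place: cyclohexyl in place of 2-phenylethenyl on an aromatic carbon. For the measured compounds named here, no pair of measured compounds shows a step of this kind, and the three measured numbers sit close together although each carries a different group on the same ring carbon. The expectation is therefore a step of a 1.3-fold higher number from compound 3 to compound 4 (0.13 log units; within the scatter) that stays within the scatter, leaning if anything toward a slightly higher number. Compound 4 is estimated at 9500 nM in this assay, with a range from 4000 nM to 25000 nM.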

Compound 4, half-maximal inhibitory concentration: 6100 nM
Estimate against measurement, compound 4: 1.6-fold (0.19 log units) above, within the range that was stated.
By their numbers in this assay, from the lowest: compounds 4, 3, 2 and 1 (each within the scatter of the next, the first and the last beyond it).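

In this assay, for the compounds shown here, this position gives its only measured single-place step: a 1.2-fold lower number from compound 3 to compound 4 (0.07 log units; within the scatter). An open-chain linker with a six-membered aromatic ring of carbon only, 8 heavy atoms in all, and a six-membered non-aromatic ring of 6 heavy atoms therefore give numbers that cannot be told apart on this aromatic carbon, so neither the aromatic ring nor the double bond outside it is shown to be needed for the reading here. No measurement on hand bears on why these two groups read so closely.

On these data alone, whether any group on this carbon can move the number beyond the scatter stays open, for instance an amine, a carboxylic acid or a longer straight carbon chain. The compounds shown also leave open whether a much smaller group, such as methyl, would read the same.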